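This account rests on a few compounds, and the source may have more. Where it says the series, first, only, none or still open, it means among the compounds named here.

Measured in an ADME assay on CHO-K1 cells (Cricetulus griseus) for cytotoxicity, read by MTT assay, with a stated time of 24 h; on this read-out lower numbers stand for higher toxicity in this test and higher numbers for lower toxicity in this test:
- compound 1 `Oc1ccccc1NC(=S)Nc1ccc2[nH]ccc2c1`: 509000 nM
- compound 2 `OCc1ccc(NC(=S)Nc2ccc3[nH]ccc3c2)cc1`: 1080000 nM

Of the two numbers in this assay, compound 2 has the higher, at 1080000 nM. Compound 1 lies lower at 509000 nM, and this gap is beyond the usual scatter. Compound 2 therefore marks the low-toxicity end of this small set.

The next compound to be read is compound 3 `CC(=O)c1ccc(NC(=S)Nc2ccc3[nH]ccc3c2)cc1`, which differs from compound 2 by one change: acetyl in place of hydroxymethyl on an aromatic carbon.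

Within the data shown here, no step between measured compounds shows what a single change does here, so the expectation is weakly founded. Among the measured compounds shown here, the only guide to size is the gap between the two measured values, and compound 2 sits at the top of that short range. The expected change is a modest fall in the number, a 1.7-fold lower number from compound 2 to compound 3 (0.22 log units; within the scatter). It may well stay within the scatter. For compound 3 the estimated value is 650000 nM, with an expected range of 250000 nM to 1400000 nM.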

Compound 3, concentration lethal to 50% of the cells: 154000 nM
The estimate for compound 3 lay 4.2-fold (0.63 log units) above the measured number; the whole stated range lies above it.
By their numbers in this assay, from the lowest: compound 3; then compound 1; then compound 2.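

In this assay, the series now has its first step that changes one place, and that step is beyond the scatter: acetyl in place of hydroxymethyl, on an aromatic carbon para to a large group, gives a 7.0-fold lower number from compound 2 to compound 3 (0.85 log units; beyond the scatter). The number at this position therefore depends on the group it carries, and in this pair the toxicity in this test is higher with acetyl. The change removes the hydrogen-bond donor of hydroxymethyl and brings in a double bond outside aromatic rings and a larger heavy-atom count, but this single step cannot separate these differences, and nothing measured here explains the fall.

As far as these compounds go, it remains open whether the number follows the carbonyl of acetyl or something else that separates the two groups, and a carboxylic acid, an amine or a longer chain at the same position would help to tell these apart. From the compounds shown here alone, it is also open whether the same exchange would give a step of similar size at another position on this aromatic ring.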